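A few compounds are considered here, and "the series" means these few. Any claim that something is new, unique, unknown or untested is made for them only; others in the source may bear on it.

Measured so far in an in vitro ADME assay on microsomes from liver (Homo sapiens) for pharmacokinetics, read by LC-MS, with a stated time of 10 min, tested at 1 uM; a lower number here means slower removal, a higher number faster removal of the compound:

compound 1 `Cc1ccc(NC(=O)[C@H]2CN(C)C[C@@H]2c2ccc(/C=C/C(=O)Nc3ccccc3N)cc2)cc1` gives 15 mL/min/kg
compound 2 `COc1ccc(NC(=O)[C@H]2CN(C)C[C@@H]2c2ccc(/C=C/C(=O)Nc3ccccc3N)cc2)cc1` gives 14 mL/min/kg
compound 3 `CN1C[C@H](C(=O)Nc2cccc(F)c2)[C@@H](c2ccc(/C=C/C(=O)Nc3ccccc3N)cc2)C1` gives 6 mL/min/kg

Compound 3 holds the lowest number of the three in this assay; its nearest neighbour is compound 2 and the furthest is compound 1, both separated from it by steps beyond the scatter. Compound 4 `Cc1ccc(NC(=O)[C@H]2CN(C)C[C@@H]2c2ccc(/C=C/C(=O)Nc3ccccc3N)cc2)cn1` is not yet measured. It differs from compound 3 in one place: 6-methylpyridin-3-yl in place of 3-fluorophenyl on an amide-type nitrogen.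

Going by the values given here, two measured steps bear on this position, the exchange of the group on the amide-type nitrogen. They are a 2.5-fold lower number from compound 1 to compound 3 (0.40 log units; beyond the scatter) and a 2.3-fold lower number from compound 2 to compound 3 (0.37 log units; beyond the scatter), both modest and in the same direction, while a 1.1-fold lower number from compound 1 to compound 2 (0.03 log units; within the scatter) shows that methyl against methoxy made no difference beyond the scatter. Among the compounds with values here, the new group of compound 4 is neither of the groups already measured at this place, so no step maps onto it directly. Leaving the 3-fluorophenyl of compound 3 is expected to undo some of the drop seen in going from compound 1 and compound 2, so a modest rise is estimated: a 1.7-fold higher number from compound 3 to compound 4 (0.22 log units; within the scatter). For compound 4 the expected value in this assay is 10 mL/min/kg, with a range from 5 mL/min/kg to 20 mL/min/kg.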

Compound 4, clearance: 8 mL/min/kg
For compound 4 the middle estimate is 1.3-fold (0.10 log units) above the measured one; measured number inside the range.
By their numbers in this assay, from the lowest: compounds 3, 4, 2 and 1 (each within the scatter of the next, the first and the last beyond it).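

In this assay, 6-methylpyridin-3-yl on the amide-type nitrogen is the only group shown with a hetero atom in its aromatic ring, and exchanging 3-fluorophenyl for it gives a 1.3-fold higher number from compound 3 to compound 4 (0.12 log units; within the scatter). Going by these compounds alone, the same group also stays within the scatter of the two other groups, with a 1.8-fold lower number from compound 2 to compound 4 (0.24 log units; within the scatter) and a 1.9-fold lower number from compound 1 to compound 4 (0.27 log units; within the scatter), so compound 4 separates from none of the measured compounds, whereas compound 3 separates from both compound 1 and compound 2. No measurement at hand gives a reason for these numbers.

Open is what an unsubstituted pyridin-3-yl or a saturated cyclohexyl on the amide-type nitrogen would give, as the aromatic groups shown span only a narrow set. From the compounds shown here alone, all four compounds share one core, so how these steps carry over to any other core also remains open.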